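Shortening the chain of compound 2 by one carbon

This account rests on a few compounds, and the source may have more. Where it says the series, first, only, none or still open, it means among the compounds named here.

compound 1 `CNC(=O)CCCCCCCn1nc(-c2cnc3[nH]ccc3c2)c2c(N)ncnc21`: 15800 nM
compound 2 `Nc1nc2cc(-c3nn(CCCCCCCCCC(=O)NO)c4ncnc(N)c34)ccc2o1`: > 50000 nM (a limit, not a number)
compound 3 `Nc1ncnc2c1c(-c1cnc3[nH]ccc3c1)nn2CCCCCCCCCC(=O)NO`: 10100 nM

In a functional assay on MDA-MB-231 cells (Homo sapiens) for inhibition, read by MTT assay, with a stated time of 72 h (a lower number here means a stronger inhibitor, a higher number a weaker inhibitor), compound 2 gives only a limit, > 50000 nM. Compound 4 `Nc1nc2cc(-c3nn(CCCCCCCCC(=O)NO)c4ncnc(N)c34)ccc2o1` changes only the chain end of compound 2, with hydroxycarbamoyl in place of (hydroxycarbamoyl)methyl on a saturated chain carbon, eight bonds along the chain from an aromatic nitrogen. Among the measured compounds shown here, two measured steps bear on this. The chain end also changed in a 1.6-fold lower number from compound 1 to compound 3 (0.19 log units; within the scatter), and that step stayed small. The larger step, an at least 4.9-fold lower number from compound 2 to compound 3 (0.69 log units; beyond the scatter), swapped the group on the aromatic carbon, and compound 4 keeps the group of compound 2. No clear shift is therefore expected, and the expected result is a number no higher from compound 2 to compound 4 (the limit leaves the size open). Compound 4 is estimated at 50000 nM, with an expected range of 20000 nM to 120000 nM.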

Compound 4, half-maximal inhibitory concentration: 30300 nM
For compound 4 the middle estimate is 1.7-fold (0.22 log units) above the measured one, and the stated range covers the measured number.
By their numbers in this assay, from the lowest: compounds 3, 1 and 4 (each within the scatter of the next, the first and the last beyond it). At a limit, above all of these: compound 2.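

In this assay, the shorter chain end, hydroxycarbamoyl in place of (hydroxycarbamoyl)methyl, gives an at least 1.6-fold lower number from compound 2 to compound 4 (0.21 log units; that floor lies within the scatter). Compound 4 shows that a chain end change on this core can yield a measured number, whereas compound 2 gives only a limit. The true size of the step stays unknown, because one end of it is that limit: the limit of > 50000 nM in this assay, at which 1 of the 4 values shown sits.

As far as these compounds go, whether a carboxylic acid or an amine at the chain end would change the number on this core remains open. So does the effect of a still shorter chain.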